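The source may hold more compounds than are shown below. What is called first, only, known or untested is meant among the compounds shown, and "the series" means these compounds.

Compound 1 `CN1CCN(Cc2nnc(-c3cc(S(N)(=O)=O)c(SCc4ccccc4)cc3Cl)o2)CC1` gives 0.308 h in an ADME assay on microsomes from liver (Homo sapiens) for metabolic stability, read by LC-MS, using NADPH, tested at 5 uM; on this read-out lower numbers stand for a shorter-lived compound and higher numbers for a longer-lived compound.
Compound 2 `[N-]=[N+]=NCc1nnc(-c2cc(S(N)(=O)=O)c(SCc3ccccc3)cc2Cl)o1` gives > 1 h in this assay; this is a limit of the assay and not a number.

Compound 1 and compound 2 share one core and differ only in the group on the saturated chain carbon bound to an aromatic carbon. Going by the values given here, the single measured step, an at least 3.2-fold higher number from compound 1 to compound 2 (0.51 log units; beyond the scatter), carries compound 2 up to the limit, so that compound 2 stands at the upper end of what has been seen, a point described by the limit of > 1 h in this assay, at which 1 of the 2 values shown sits.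

Compound 3 `CCOC(=O)c1cn(Cc2nnc(-c3cc(S(N)(=O)=O)c(SCc4ccccc4)cc3Cl)o2)nn1` takes this further: 4-(ethoxycarbonyl)-1H-1,2,3-triazol-1-yl in place of azido on a saturated chain carbon bound to an aromatic carbon. Among the compounds with values here, no measured step covers a change of this kind; the only step on record, from compound 1 to compound 2, concerns the exchange at the same position but with different groups, and it says nothing about a triazole ester. What can be said is that compound 2 already sits at the limit, so compound 3 starts from a long-lived parent.

Compound 3 is therefore expected to give about 1 h in this assay, within a range of 0.4 h to 2.5 h, which would mean a step of a number no higher from compound 2 to compound 3 (the limit leaves the size open) that is not beyond the scatter.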

Compound 3, half-life: 0.085 h
Beside the measured number, compound 3's estimate is 12-fold (1.07 log units) above it, outside the stated range (below it).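

In this assay, the group on the saturated chain carbon bound to an aromatic carbon now proves able to move the half-life in either direction: the earlier pair showed only a rise, whereas the exchange of azido for 4-(ethoxycarbonyl)-1H-1,2,3-triazol-1-yl gives an at least 11-fold lower number from compound 2 to compound 3 (1.07 log units; beyond the scatter). The new group also falls short of the 4-methylpiperazin-1-yl group, with a 3.6-fold lower number from compound 1 to compound 3 (0.56 log units; beyond the scatter), so compound 3 holds the shortest half-life of the three and the position spans a wider range than the first step revealed. On these data alone, the true size of the drop from azido stays unknown, since compound 2 is recorded only as a limit of the assay and not as a number: the limit of > 1 h in this assay, at which 1 of the 3 values shown sits.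

The compounds shown leave open whether the loss of half-life goes with the ethyl ester or with the triazole ring itself. A carboxylic acid or a primary amide in place of the ester on the same triazole, or a triazole without any ester, would separate the two.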